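Replacing isopropoxy by formyl on the shared core

The source may hold more compounds than are shown below. What is called first, only, known or untested is meant among the compounds shown, and "the series" means these compounds.

Of the compounds shown here, three on one core have been measured in an assay on CHO cells for displacement of a labelled ligand from Alpha-2B adrenergic receptor (Homo sapiens); a lower number here means a stronger inhibitor, a higher number a weaker inhibitor. Compound 1 `C=C(C)c1ccccc1OC(C)C1=NCCN1` gives 871 nM, compound 2 `CC(C)Oc1ccccc1OC(C)C1=NCCN1` gives 1580 nM, and compound 3 `CC(Oc1ccccc1S(C)(=O)=O)C1=NCCN1` gives 51300 nM. Compound 2 therefore holds the second highest of the three numbers, with compound 1 nearest, a 1.8-fold higher number from compound 1 to compound 2 (0.26 log units; within the scatter), and compound 3 furthest.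

Compound 4 `CC(Oc1ccccc1C=O)C1=NCCN1` differs from compound 2 in one place: formyl in place of isopropoxy on an aromatic carbon. Among the measured compounds shown here, two measured steps bear on this change. Exchanging the group on that aromatic carbon between 1-methylethenyl and isopropoxy left the number essentially unchanged, whereas moving to methylsulfonyl brought a 59-fold higher number from compound 1 to compound 3 (1.77 log units; beyond the scatter) and a 32-fold higher number from compound 2 to compound 3 (1.51 log units; beyond the scatter). Formyl carries, like methylsulfonyl, one hydrogen-bond acceptor, but it is smaller, so a weakening of binding is expected, though less than that seen for compound 3. The estimate for compound 4 means a 3.8-fold higher number from compound 2 to compound 4 (0.58 log units; beyond the scatter), expected to lie beyond the scatter. Compound 4 is expected at 6000 nM, within 1500 nM to 25000 nM.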

Compound 4, inhibition constant: 2090 nM
For compound 4 the middle estimate is 2.9-fold (0.46 log units) above the measured one; the range from low to high includes it.
By their numbers in this assay, from the lowest: compounds 1, 2 and 4 (each within the scatter of the next, the first and the last beyond it); then compound 3.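

In this assay, formyl, with 2 heavy atoms, stands in for isopropoxy, with 4, without a step beyond the scatter (a 1.3-fold higher number from compound 2 to compound 4 (0.12 log units; within the scatter)), so this aromatic carbon accepts the smaller group here as well as the larger one. The large step seen with methylsulfonyl is thus not common to every group tried at this place (a 25-fold lower number from compound 3 to compound 4 (1.39 log units; beyond the scatter)), although formyl does stand modestly apart from 1-methylethenyl (a 2.4-fold higher number from compound 1 to compound 4 (0.38 log units; beyond the scatter)), and among these four compounds only compound 3 lies far from the others. Nothing measured here accounts for these differences.

As far as these compounds go, it remains open whether an amine, a carboxylic acid or a longer carbon chain on this aromatic carbon would stay with compounds 1, 2 and 4 or move towards compound 3. From the compounds shown here alone, whether formyl would behave the same way on any other core also remains open.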